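Ester to Ether Swap on the Shared Core

The source may report more compounds than this note shows. Statements on the series, on what has been measured and on what is new or still open speak of the compounds shown alone.

Compound 1 `CC(C)=CC[C@@H](OC(=O)CCO)C1=CC(=O)c2c(O)ccc(O)c2C1=O`, compound 2 `CC(C)=CC[C@@H](OC(=O)c1ccco1)C1=CC(=O)c2c(O)ccc(O)c2C1=O`, compound 3 `COCCO[C@H](CC=C(C)C)C1=CC(=O)c2c(O)ccc(O)c2C1=O` and the still unmeasured compound 4 `CCC(CO[C@H](CC=C(C)C)C1=CC(=O)c2c(O)ccc(O)c2C1=O)OC(C)=O` share one core and differ only in the group on an oxygen on a saturated carbon. In a functional assay on DU-145 cells (Homo sapiens) for cytotoxicity, read by MTT assay (on this read-out higher numbers stand for weaker inhibition and lower numbers for stronger inhibition), compound 1 gives 55300 nM and compound 3 gives 43200 nM. For compound 2 the assay reports only a limit, > 100000 nM, so compound 2 stands as a limit rather than a number among the three. Compound 4 arises from compound 2 by 2-acetoxybutyl in place of (furan-2-yl)carbonyl on an oxygen on a saturated carbon. The step of an at least 2.3-fold lower number from compound 2 to compound 3 (0.36 log units; beyond the scatter) likewise replaces the (furan-2-yl)carbonyl with a chain, while a 1.3-fold lower number from compound 1 to compound 3 (0.11 log units; within the scatter) stays within the scatter. A similar, modest fall in number is expected for compound 4, an at least 2.0-fold lower number from compound 2 to compound 4 (0.30 log units; that floor lies within the scatter). Compound 4 is therefore estimated at 50000 nM, ranging from 20000 nM to 150000 nM.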

Compound 4, half-maximal inhibitory concentration: 25400 nM
Compound 4: middle estimate off by 2.0-fold (0.29 log units), on the high side, and the stated range covers the measured number.
By their numbers in this assay, from the lowest: compounds 4, 3 and 1 (each within the scatter of the next, the first and the last beyond it). At a limit, above all of these: compound 2.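

Compound 2 is known only as a limit: the limit of > 100000 nM in this assay, at which 1 of the 4 values shown sits. Even so, 2-acetoxybutyl on this oxygen gives a clear step down from the furan-2-yl ester, an at least 3.9-fold lower number from compound 2 to compound 4 (0.59 log units; beyond the scatter), and, unlike the 2-methoxyethyl of compound 3, also a step beyond the scatter from the (2-hydroxyethyl)carbonyl group, a 2.2-fold lower number from compound 1 to compound 4 (0.34 log units; beyond the scatter). The two ether chains themselves cannot be told apart, a 1.7-fold lower number from compound 3 to compound 4 (0.23 log units; within the scatter).

Going by these compounds, whether the acetoxy part of the chain matters stays open. A plain butyl chain, or a chain ending in an amine or a carboxylic acid, could show how far this position tolerates change.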